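Series Notes: Cytotoxicity in A549 Cells, Compound 2 to 3

The compounds below may be only part of what the source reports. "The series", "measured", "known", "first", "only" and "open" are said of these compounds alone.

Measured so far:
compound 1 `C=C1C[C@]23C[C@@]1(O)CC[C@H]2c1ccc(OS(=O)(=O)c2ccc(C)cc2)c(C)c1[C@@H]3Cn1cc(-c2ccc(OC)cc2)nn1` — in a functional assay on A549 cells (Homo sapiens) for cytotoxicity, read by MTT assay, with a stated time of 4 days (on this read-out lower numbers stand for stronger inhibition and higher numbers for weaker inhibition), compound 1 gives > 20000 nM, a limit of the assay and not a number.
compound 2 `C=C1C(=O)[C@]23C[C@@]1(O)CC[C@H]2c1ccc(OS(=O)(=O)c2ccc(C)cc2)c(C)c1[C@@H]3Cn1cc(-c2ccc(C)cc2)nn1` — in this assay compound 2 gives 1830 nM.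

Compound 2 thus holds the only number shown; the other value sits at the limit of > 20000 nM in this assay, at which 1 of the 2 values shown sits. Compound 3 `C=C1C(=O)[C@]23C[C@@]1(O)CC[C@H]2c1ccc(OS(=O)(=O)c2ccc(C)cc2)c(C)c1[C@@H]3Cn1cc(-c2ccc(Br)cc2)nn1` is not yet measured and differs from compound 2 by bromo in place of methyl on an aromatic carbon. Among the compounds with values here, no measured pair shows this difference, so the step in this assay is expected to be a 1.2-fold lower number from compound 2 to compound 3 (0.09 log units; within the scatter), no larger than the usual scatter, in either direction. Compound 3 is therefore estimated at 1500 nM in this assay, with a range from 500 nM to 5000 nM.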

Compound 3, half-maximal inhibitory concentration: 1630 nM
The estimate for compound 3 lay 1.1-fold (0.04 log units) below the measured number; low and high end bracket the measured number.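

In this assay, the exchange of 4-methylphenyl for 4-bromophenyl, para to a large group, gives a 1.1-fold lower number from compound 2 to compound 3 (0.05 log units; within the scatter). Within the data shown here, this is the first pair that differs in one place, and it shows that this position accepts bromo in place of methyl with no change beyond the scatter. Nothing shown here bears on a cause for this step.

From the compounds shown here alone, whether an amine or a carboxylic acid at this position would shift the number remains open. Going by these compounds, the role of the carbonyl in compound 2 also remains open, since compound 1 differs from it in more than one place and gives only a limit.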